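Replacing 2-chloroethyl with 4-(trifluoromethyl)phenyl on a carbonyl

The source may hold more compounds than are shown below. What is called first, only, known or untested is meant among the compounds shown, and "the series" means these compounds.

The measured compounds and their numbers:
Compound 1, `CN(C)c1ccc(C2CC(c3ccc(-n4cncn4)cc3)=NN2)cc1`, gives -3.3% in a functional assay on NCI-H1975 cells (Homo sapiens) for inhibition, read by sulforhodamine B assay, tested at 10 uM; on this read-out lower numbers stand for less inhibition and higher numbers for more inhibition at the one concentration tested (going by the name of the read-out).
Compound 2, `CC(=O)N1N=C(c2ccc(N3CCN(C)CC3)cc2)CC1c1ccc(N(C)C)cc1`, gives -1.9% in this assay.
Compound 3, `CN1CCN(c2ccc(C3=NN(C(=O)CCCl)C(c4ccc(N(C)C)cc4)C3)cc2)CC1`, gives -0.2% in this assay.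

All three numbers sit close to zero. Among the compounds with values here, the only single-point step among them, a number 1.7 percentage points higher from compound 2 to compound 3 (within the scatter), changes nothing beyond the scatter. Compound 1 and compound 3 are not joined by a single-point step; their two values show a gap that also lies within the scatter. Compound 3 therefore stands among numbers that cannot be told apart.

Compound 4, `CN1CCN(c2ccc(C3=NN(C(=O)c4ccc(C(F)(F)F)cc4)C(c4ccc(N(C)C)cc4)C3)cc2)CC1`, differs from compound 3 in one place: 4-(trifluoromethyl)phenyl in place of 2-chloroethyl on a carbonyl carbon. Within the data shown here, no measured step bears on this kind of exchange; the one step known concerns chloromethyl in place of hydrogen on a saturated chain carbon bound to a carbonyl carbon, and it was within the scatter. With every number in this series near zero and no step beyond the scatter, the estimate for compound 4 in this assay is 0%, with a range from -10% to 12%. The expected step of a number 0.2 percentage points higher from compound 3 to compound 4 (within the scatter) is, on this estimate, one that stays within the scatter.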

Compound 4, a percentage reported as inhibition, at one concentration (the size of the read-out at that concentration, not a potency): 93.2%
Compound 4: the middle estimate sits 93.2 percentage points below what was measured, outside the stated range (above it).
By their numbers in this assay, from the lowest: compounds 1, 2 and 3 (each within the scatter of the next); then compound 4.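

In this assay, the group on the carbonyl carbon bound to the amide-type nitrogen in a ring turns out to govern the read-out: 4-(trifluoromethyl)phenyl in place of 2-chloroethyl gives a number 93.4 percentage points higher from compound 3 to compound 4 (beyond the scatter), and the same group in place of methyl gives a number 95.1 percentage points higher from compound 2 to compound 4 (beyond the scatter). The earlier exchange at this carbonyl, a number 1.7 percentage points higher from compound 2 to compound 3 (within the scatter), had given no sign of this, so the position seemed silent only as long as it carried small open chains; with the two large steps, the same shared core goes from numbers near zero to a clear inhibition. Nothing in the material shown explains why this exchange has so large an effect.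

The compounds shown cannot separate the share of the aromatic ring from that of the trifluoromethyl group: a plain phenyl, a phenyl bearing a methoxy group or a nitrile, or a saturated ring such as cyclohexyl on this carbonyl would speak to that. Compound 4 also gives 93.2% at a single concentration, which states the size of the read-out at that concentration and leaves its potency open.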